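Ring Swap on the Aromatic Carbon of Compound 1

The compounds below may be only part of what the source reports. "The series", "measured", "known", "first", "only" and "open" are said of these compounds alone.

Compound 1 `CC(C)N1CCC(c2ccc3c(c2)oc(=O)n3C(=O)NCCCCc2ccccc2)CC1` gives the lowest number of the three measured compounds in an assay on HEK293 cells for inhibition of acid ceramidase (Homo sapiens), read by fluorescence, with stated times of 10 min and 3 h (on this read-out higher numbers stand for weaker inhibition and lower numbers for stronger inhibition), at 94 nM. Compound 2 `O=C(NCCCCc1ccccc1)n1c2c(oc1=O)CNCC2` gives 340 nM in this assay, and compound 3 `O=C(NCCCCc1ccccc1)n1c2c(oc1=O)CCN(Cc1ccccc1)C2` gives 436 nM; both of these values lie beyond the scatter from the value of compound 1. Compound 4 `CCN1CCN(c2ccc3c(c2)oc(=O)n3C(=O)NCCCCc2ccccc2)CC1` is not yet measured. It differs from compound 1 in one place: 4-ethylpiperazin-1-yl in place of 1-isopropylpiperidin-4-yl on an aromatic carbon. Within the data shown here, no measured pair shows a change of this kind, so the size of the step cannot be read from the data; the rest of the molecule is kept. A step of modest size, toward a higher number or none beyond the scatter, is expected, giving a 1.7-fold higher number from compound 1 to compound 4 (0.23 log units; within the scatter). For compound 4 the expected value in this assay is 160 nM, with a range from 55 nM to 470 nM.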

Compound 4, half-maximal inhibitory concentration: 56 nM
Beside the measured number, compound 4's estimate is 2.9-fold (0.46 log units) above it; measured number inside the range.
By their numbers in this assay, from the lowest: compounds 4 and 1 (each within the scatter of the next); then compounds 2 and 3 (each within the scatter of the next).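

On the aromatic carbon, 4-ethylpiperazin-1-yl in place of 1-isopropylpiperidin-4-yl gives a 1.7-fold lower number from compound 1 to compound 4 (0.22 log units; within the scatter) in this assay. Among these compounds, this is the first measured pair differing in one place, and it shows that this position accepts a six-membered ring with 2 hetero atoms as well as one with 1 hetero atom, with no step beyond the scatter. No further evidence bears on this result.

The ring and its alkyl group change together here, so their separate shares cannot be read. As far as these compounds go, whether a morpholine or a 4-propylpiperazin-1-yl group at this carbon would stay within the scatter remains open.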